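From compound 3 to compound 4: one group exchanged

This account rests on a few compounds, and the source may have more. Where it says the series, first, only, none or still open, it means among the compounds named here.

Measured so far in a toxicity assay on microsomes from liver (Homo sapiens) for metabolic stability, read by LC-MS, using NADPH, tested at 1 uM; on this read-out lower numbers stand for slow clearance and higher numbers for fast clearance:
compound 1 `Cc1nc(-c2nc3ccccc3[nH]2)c(N2CCN(C(=O)Cn3cnc4cccnc43)[C@H](C)C2)s1` gives 23 mL.min-1.g-1
compound 2 `C[C@@H]1CN(c2sc(CN(C)C)nc2-c2nc3ccccc3[nH]2)CCN1C(=O)Cn1cnc2cccnc21` gives 44 mL.min-1.g-1
compound 3 `CCOc1ncc(-c2nc(C(F)(F)F)sc2N2CCN(C(=O)Cn3ncc4cccnc43)[C@H](C)C2)cn1` gives 41 mL.min-1.g-1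

Compound 3 at 41 mL.min-1.g-1 stands within the scatter of compound 2 at 44 mL.min-1.g-1 and also of compound 1 at 23 mL.min-1.g-1 so these numbers do not rank the three compounds.

Compound 4 `CCOc1ncc(-c2nc(C(F)(F)F)sc2N2CCN(C(=O)Cn3nc(C)nc3C)[C@H](C)C2)cn1` has not yet been measured. It differs from compound 3 by a group of 7 heavy atoms (4 carbon, 3 nitrogen; one five-membered aromatic ring with 3 hetero atoms) in place of a group of 9 heavy atoms (6 carbon, 3 nitrogen; one five-membered aromatic ring with 2 hetero atoms, one six-membered aromatic ring with 1 hetero atom), on a saturated chain carbon bound to a carbonyl carbon and the group that enters is 3,5-dimethyl-1H-1,2,4-triazol-1-yl.

For the measured compounds named here, only one measured step is available, a 1.9-fold higher number from compound 1 to compound 2 (0.28 log units; within the scatter) and it lies within the scatter. That step puts dimethylamino in place of hydrogen on a saturated chain carbon bound to an aromatic carbon, so it is a different exchange in a different place. Going by the values given here, no measured pair tests a change on a saturated chain carbon bound to a carbonyl carbon. The data therefore give no direction, and no step beyond the scatter is expected in this assay for this exchange. The expected change is a 1.1-fold lower number from compound 3 to compound 4 (0.03 log units; within the scatter) and it is estimated to stay within the scatter. For compound 4 the expected value is 38 mL.min-1.g-1 with 19 mL.min-1.g-1 to 76 mL.min-1.g-1 as the estimated range.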

Compound 4, intrinsic clearance in microsomes: < 10 mL.min-1.g-1
Compound 4 gave a limit, no number (the forecaster's own chance of this, stated with the estimate: 3%); at least 3.8-fold (0.57 log units) between middle value and limit.
By their numbers in this assay, from the lowest: compounds 1, 3 and 2 (each within the scatter of the next). At a limit, below all of these: compound 4.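

In this assay, the exchange on a saturated chain carbon bound to a carbonyl carbon gives an at least 4.1-fold lower number from compound 3 to compound 4 (0.61 log units; beyond the scatter), the only step beyond the scatter among the compounds shown, so this position, which no earlier pair tested, is one at which the clearance read-out can move. The group that leaves holds a five-membered and a six-membered aromatic ring, whereas 3,5-dimethyl-1H-1,2,4-triazol-1-yl holds a single five-membered aromatic ring, and the two groups match in hydrogen-bond donors, hydrogen-bond acceptors and net charge, so the step arises without a change in any of those counts. Compound 4 stands at a limit of the assay and not at a number, which leaves the size of the step open on one side: the limit of < 10 mL.min-1.g-1 in this assay, at which 1 of the 4 values shown sits.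

This single exchange alters the ring system, the hetero atoms and the methyl groups together, so the compounds shown cannot say which of these changes carries the step. They also leave open how an unmethylated triazole, a morpholine or a carboxylic acid at this chain carbon would read, and whether the same exchange would give a similar step on the core of compound 1.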